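The source may report more compounds than this note shows. Statements on the series, on what has been measured and on what is new or still open speak of the compounds shown alone.

Measured compounds:
Compound 1 `COc1cccc(S(=O)(=O)Nc2ccc3oc(-c4ccccc4)nc3c2)c1` — in an assay on cells for inhibition of HSP60/HSP10 (Homo sapiens), with a stated time of 60 min (on this read-out higher numbers stand for weaker inhibition and lower numbers for stronger inhibition), compound 1 gives > 100000 nM, which is a limit of the assay and not a number.
Compound 2 `CCc1ccc(S(=O)(=O)Nc2ccc3oc(-c4ccccc4)nc3c2)cc1` — in this assay compound 2 gives > 100000 nM, likewise a limit of the assay.

Among the measured compounds shown here, compound 2 therefore has no measured number to stand on; its value is a limit, and the only other value shown is the same kind of limit, so both sit at the limit of > 100000 nM in this assay, at which 2 of the 2 values shown sit. For the measured compounds named here, the single measured step in this assay, a step that the two limits leave unreadable from compound 1 to compound 2, cannot be read in either direction or in size.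

Compound 3 `O=S(=O)(Nc1ccc2oc(-c3ccccc3)nc2c1)c1ccc(Cl)s1` differs from compound 2 by one change: 5-chlorothiophen-2-yl in place of 4-ethylphenyl on a sulfonyl sulfur. Going by the values given here, the only measured step that touches this part of the shared core is the unreadable one from compound 1 to compound 2, so there is no measured size of step that bears on the new change. With nothing to suggest a readable improvement, compound 3 is expected to remain at or near the limit, and any real step beyond the scatter is not foreseen. The estimate for compound 3 in this assay is 100000 nM, with a range from 20000 nM to 400000 nM. The expected step is therefore a number no higher from compound 2 to compound 3 (the limit leaves the size open).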

Compound 3, half-maximal inhibitory concentration: 70000 nM
For compound 3 the middle estimate is 1.4-fold (0.15 log units) above the measured one; the range from low to high includes it.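

Of the three groups shown on the sulfonyl sulfur, only 5-chlorothiophen-2-yl gives a number in this assay rather than a limit, and this gives the position its first readable steps: an at least 1.4-fold lower number from compound 2 to compound 3 (0.15 log units; that floor lies within the scatter), and an at least 1.4-fold lower number from compound 1 to compound 3 (0.15 log units; that floor lies within the scatter). Each of these is only a floor that lies within the scatter, so the result shows that the sulfonamide on the shared core can give a measurable value, but not that 5-chlorothiophen-2-yl brings a real gain over 4-ethylphenyl or 3-methoxyphenyl. The change also alters several things at once, replacing a six-membered aromatic ring of carbon only with a five-membered aromatic ring with 1 hetero atom that carries a chlorine, and the remaining values are limits of the assay: the limit of > 100000 nM in this assay, at which 2 of the 3 values shown sit.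

The compounds shown cannot separate the part played by the chlorine from that of the thiophene ring, which a thiophen-2-yl without the chlorine or a 4-chlorophenyl on the sulfonyl sulfur would help to settle. Going by these compounds, how far the true size of either step reaches also stays open, as does the effect of an amine or a carboxylic acid at this place.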